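From chloro to bromo on the shared core

The compounds below may be only part of what the source reports. "The series", "measured", "known", "first", "only" and "open" are said of these compounds alone.

In a functional assay on ASPC1 cells (Homo sapiens) for antiproliferative activity, read by sulforhodamine B assay, with a stated time of 48 h (a lower number here means a stronger inhibitor, a higher number a weaker inhibitor), compound 2 `O=C(CCCCCCN1C(=O)/C(=N\O)c2cc(Cl)ccc21)NO` gives 1860 nM and compound 1 `O=C(CCCCCCN1C(=O)/C(=N\O)c2cc(F)ccc21)NO` gives 1720 nM with nothing separating them beyond the scatter. Compound 3 `O=C(CCCCCCN1C(=O)/C(=N\O)c2cc(Br)ccc21)NO` differs from compound 2 by bromo in place of chloro on an aromatic carbon with bromo in place of chloro on an aromatic carbon. Within the data shown here, the only measured step bearing on this, chloro in place of fluoro on an aromatic carbon, is a 1.1-fold higher number from compound 1 to compound 2 (0.03 log units; within the scatter) and so no step beyond the scatter is expected in this assay here. The expected change is a 1.0-fold higher number from compound 2 to compound 3 (0.01 log units; within the scatter) and it stays within the scatter. Compound 3 is therefore estimated at 1900 nM (range 1050 nM to 3400 nM).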

Compound 3, half-maximal inhibitory concentration: 80 nM
Beside the measured number, compound 3's estimate is 24-fold (1.38 log units) above it; the whole stated range lies above it.
By their numbers in this assay, from the lowest: compound 3; then compounds 1 and 2 (each within the scatter of the next).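

In this assay this aromatic carbon proves sensitive to the choice of halogen: bromo in place of chloro gives a 23-fold lower number from compound 2 to compound 3 (1.37 log units; beyond the scatter), and bromo in place of fluoro gives a 22-fold lower number from compound 1 to compound 3 (1.33 log units; beyond the scatter), although the fluoro and chloro compounds could not be told apart. The response across these three halogens is therefore not graded, and bromo alone stands apart. Nothing given here explains the jump with bromo.

Going by these compounds, whether iodo, methyl or trifluoromethyl on this same carbon would match bromo remains open. So does whether bromo keeps this advantage with a shorter chain.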